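The source may hold more compounds than are shown below. What is called first, only, known or untested is meant among the compounds shown, and "the series" means these compounds.

Compound 1 `N#Cc1c(Nc2ccccc2)nc(SCc2nc3ccccc3[nH]2)nc1-c1ccccc1`: 8.9 nM
Compound 2 `N#Cc1c(NNC(N)=S)nc(SCc2nc3ccccc3[nH]2)nc1-c1ccccc1`: 3.2 nM
Compound 3 `N#Cc1c(-c2ccccc2)nc(SCc2nc3ccccc3[nH]2)nc1N1CCNCC1`: 2.6 nM

These three compounds share a core and differ in one group. In a functional assay on SK-MEL-28 cells (Homo sapiens) for cytotoxicity, read by MTT assay, with a stated time of 3 days (a lower number here means a stronger inhibitor, a higher number a weaker inhibitor), compound 3 gives 2.6 nM. It stands level with compound 2, as a 1.2-fold lower number from compound 2 to compound 3 (0.09 log units; within the scatter) shows, and clearly apart from compound 1, as a 3.4-fold lower number from compound 1 to compound 3 (0.53 log units; beyond the scatter) shows.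

The next compound, compound 4 `N#Cc1c(-c2ccccc2)nc(SCc2nc3ccccc3[nH]2)nc1N1CCN(S(=O)(=O)c2ccccc2[N+](=O)[O-])CC1`, has (2-nitrophenyl)sulfonyl in place of hydrogen on an amine nitrogen in a ring. Going by the values given here, no measured compound carries any group on that nitrogen, so the data do not test this change directly.

The closest evidence is a 3.4-fold lower number from compound 1 to compound 3 (0.53 log units; beyond the scatter), where piperazin-1-yl replaces anilino at the same place on the core. The other change at that place, a 2.8-fold lower number from compound 1 to compound 2 (0.44 log units; beyond the scatter), is also modest. Across these three compounds, then, quite different groups move the number only a little. The one carrying an extra aromatic ring, compound 1, has the higher number, though this is a single case.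

A modest loss is therefore expected in this assay, although the direction is uncertain. The expected change is a 2.3-fold higher number from compound 3 to compound 4 (0.36 log units; beyond the scatter). The estimate for compound 4 is 6 nM, with an expected range from 1.5 nM to 25 nM.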

Compound 4, half-maximal inhibitory concentration: 8.9 nM
Compound 4: the middle estimate sits 1.5-fold (0.17 log units) below what was measured, and the stated range covers the measured number.
By their numbers in this assay, from the lowest: compounds 3 and 2 (each within the scatter of the next); then compounds 1 and 4 (each within the scatter of the next).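

Going by these compounds alone, compound 4 gives the first direct reading on the ring nitrogen of the piperazine, which is free in compound 3: in this assay, adding (2-nitrophenyl)sulfonyl there gives a 3.4-fold higher number from compound 3 to compound 4 (0.53 log units; beyond the scatter). The step lies beyond the scatter, so the group does change the number, but it is modest for a change that adds 12 heavy atoms and a whole aromatic ring where only a hydrogen stood, and compound 4 still reads 8.9 nM. This position can therefore carry a large group without a heavy loss in this cell assay, although nothing shown explains why the number rises or what the cells respond to.

With only one group on that nitrogen, the compounds shown cannot separate the share of the sulfonyl link from that of the phenyl ring or the nitro group, and a plain benzenesulfonyl or methanesulfonyl group would begin to divide them. On these data alone, it also remains open whether a small group without sulfur on this nitrogen, such as methyl or acetyl, would leave the number level with compound 3 or move it further.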